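Adding a Methoxy Group: One Change Tried in Two Settings

The source may report more compounds than this note shows. Statements on the series, on what has been measured and on what is new or still open speak of the compounds shown alone.

Of the compounds shown here, three have so far been tested in a functional assay on MDA-MB-231 cells (Homo sapiens) for antiproliferative activity, read by sulforhodamine B assay, with a stated time of 48 h; on this read-out higher numbers stand for weaker inhibition and lower numbers for stronger inhibition. Compound 1 `COc1cc(OC)c2sc(-c3ccc(N/C=C\C(=O)c4ccc(OC)c(O)c4)c(C)c3)nc2c1` gives 3100 nM. Compound 2 `COc1ccc(C(=O)/C=C\Nc2ccc(-c3nc4cc(OC)c(OC)c(OC)c4s3)cc2C)cc1O` differs from compound 1 in a single place: methoxy in place of hydrogen on an aromatic carbon. In this assay compound 2 gives 12400 nM, and the change produced a 4.0-fold higher number from compound 1 to compound 2 (0.60 log units; beyond the scatter). Compound 3 `COc1cc(OC)c2sc(-c3ccc(N/C=C\C(=O)c4cc(OC)c(OC)c(OC)c4Br)c(C)c3)nc2c1` gives 17300 nM in this assay; the difference between the core of compound 3 and the core of compound 1 is not broken down here. Compound 4 `COc1cc(C(=O)/C=C\Nc2ccc(-c3nc4cc(OC)c(OC)c(OC)c4s3)cc2C)c(Br)c(OC)c1OC` has not yet been measured. It differs from compound 3 in one place: methoxy in place of hydrogen on an aromatic carbon, which is the same change as that from compound 1 to compound 2, made in the same surroundings. If the change acts as before, a step of similar size is expected, so compound 4 is expected to show a 3.2-fold higher number from compound 3 to compound 4 (0.50 log units; beyond the scatter) in this assay. Going by the values given here, that expectation rests on a single precedent, because a 4.0-fold higher number from compound 1 to compound 2 (0.60 log units; beyond the scatter) is the only measured instance of this change, and on compound 3 already giving 17300 nM. Compound 4 is therefore estimated at 55000 nM, with a range from 20000 nM to 150000 nM.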

Compound 4, half-maximal inhibitory concentration: 7300 nM
Compound 4: the middle estimate sits 7.5-fold (0.88 log units) above what was measured; measured number below the stated range.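

In this assay, putting a methoxy group in place of hydrogen on an aromatic carbon of the core of compound 3 gave a 2.4-fold lower number from compound 3 to compound 4 (0.37 log units; beyond the scatter), so the number moved in the opposite direction to the earlier step. Set side by side, the two steps disagree: the same change on two cores in this assay, a 4.0-fold higher number (0.60 log units; beyond the scatter) from compound 1 to compound 2 and a 2.4-fold lower number (0.37 log units; beyond the scatter) from compound 3 to compound 4, 9.5-fold (0.98 log units) apart, beyond the scatter of two such steps This shows that, for these two cores, the result of the change on one core did not predict its result on the other, but it does not show why they differ, and two pairs give no rule for any other core in the series.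

The compounds shown leave open whether a different group at the same place, such as an ethoxy group, an amine or a fluorine atom, would also move the number in opposite directions on these two cores. They also leave open which of the two steps, if either, a third core carrying the same methoxy change would follow.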